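The compounds below may be only part of what the source reports. "The series", "measured", "known", "first", "only" and "open" are said of these compounds alone.

Measured so far:
Compound 1 `CCCCCCCCCCOP(=O)(O)OCCSC(=S)N1CCCCC1`: 70700 nM
Compound 2 `CCCCCCOP(=O)(O)OCCSC(=S)N1CCCCCC1`: 70500 nM
Compound 3 `CCCCCCOP(=O)(O)OCCSC(=S)N1CCCC1`: > 100000 nM

All three compounds were tested in an ADME assay on HEK293 cells (Homo sapiens) for inhibition, read by MTT assay, with stated times of 18 h and 4 h (a lower number here means a stronger inhibitor, a higher number a weaker inhibitor), where high numbers mean weak inhibition. Compound 3 stands at the limit of > 100000 nM in this assay, at which 1 of the 3 values shown sits, so its entry is a limit and not a true number.

Compound 4 `CCCCCCOP(=O)(O)OCCSC(=S)N1CCCCC1` has not yet been measured. It differs from compound 3 at one place, with piperidin-1-yl in place of pyrrolidin-1-yl on a thiocarbonyl carbon.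

Going by the values given here, the one measured step that changes the group at this place is an at least 1.4-fold higher number from compound 2 to compound 3 (0.15 log units; that floor lies within the scatter). That step is small and gives only a floor, so it offers weak guidance. Compound 1 also carries piperidin-1-yl and gives 70700 nM, but it differs from compound 4 elsewhere too. Compound 2 gives 70500 nM, a close match to compound 1 and well within the usual scatter of it.

Together these values suggest a modest shift toward a lower number in this assay, possibly none beyond the scatter, and the assay may again report only a limit. The expected change is an at least 1.1-fold lower number from compound 3 to compound 4 (0.04 log units; that floor lies within the scatter). For compound 4 the estimate is 90000 nM, with an expected range of 60000 nM to 140000 nM.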

Compound 4, half-maximal inhibitory concentration: > 100000 nM
Compound 4 ended at the assay's limit (the forecaster's own chance of this, stated with the estimate: 45%); middle value at least 1.1-fold (0.04 log units) from the limit.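

In this assay, compound 4 gives > 100000 nM, which is a limit of the assay and not a true number, and compound 3 also carries a limit, so the step from piperidin-1-yl to pyrrolidin-1-yl on the thiocarbonyl carbon cannot be read. Two other comparisons give only floors that stay within the scatter: azepan-1-yl replaced by piperidin-1-yl gives an at least 1.4-fold higher number from compound 2 to compound 4 (0.15 log units; that floor lies within the scatter), and hydrogen in place of butyl on a saturated chain carbon, six bonds along the chain from an oxygen on an unsaturated carbon, gives an at least 1.4-fold higher number from compound 1 to compound 4 (0.15 log units; that floor lies within the scatter). The new result therefore adds a second compound at the ceiling of the assay, leaving less of this small set with a true number: the limit of > 100000 nM in this assay, at which 2 of the 4 values shown sit.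

As far as these compounds go, the true values of compound 3 and compound 4 remain unknown, as does the size of any real difference between the ring groups or between the chain lengths. From the compounds shown here alone, it also remains open whether a morpholin-4-yl group on the thiocarbonyl carbon, or a longer chain on the phosphate oxygen, would give a number that could be read within this assay's range.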